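A few compounds are considered here, and "the series" means these few. Any claim that something is new, unique, unknown or untested is made for them only; others in the source may bear on it.

Measured in an ADME assay for solubility, read by HPLC, in simulated intestinal fluid; a higher number here means a more soluble compound, a lower number a less soluble compound
compound 1 `CNS(=O)(=O)Nc1cccc(Cc2c(C)c3ccc(Oc4ncccn4)cc3oc2=O)c1` gives 29 ug/mL
compound 2 `CNS(=O)(=O)Nc1cccc(Cc2c(C)c3ccc(Oc4nccs4)cc3oc2=O)c1` gives 9 ug/mL

Compound 2 holds the lower of the two numbers (9 ug/mL). Compound 3 `CNS(=O)(=O)Nc1cccc(Cc2c(C)c3ccc(Oc4nccs4)cc3oc2=O)c1F` carries fluoro in place of hydrogen on an aromatic carbon, ortho to a (methylsulfamoyl)amino group (fluoro in place of hydrogen on an aromatic carbon). Within the data shown here, the one measured step (a 3.2-fold lower number from compound 1 to compound 2 (0.51 log units; beyond the scatter)) changed a different group, so it shows only that a single swap can move this assay and gives no direct guide to fluoro. With so little to go on, the expected change stays within the scatter (a 1.1-fold lower number from compound 2 to compound 3 (0.05 log units; within the scatter)). For compound 3 the estimated value is 8 ug/mL (expected range 3 ug/mL to 20 ug/mL).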

Compound 3, solubility: 15 ug/mL
Compound 3: the middle estimate sits 1.9-fold (0.27 log units) below what was measured, within the range that was stated.
By their numbers in this assay, from the lowest: compounds 2, 3 and 1 (each within the scatter of the next, the first and the last beyond it).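

In this assay, fluoro in place of hydrogen on an aromatic carbon, ortho to a (methylsulfamoyl)amino group, gives a 1.7-fold higher number from compound 2 to compound 3 (0.22 log units; within the scatter) and so stays within the scatter, whereas the earlier swap on the oxygen, a 3.2-fold lower number from compound 1 to compound 2 (0.51 log units; beyond the scatter), went beyond it. At this position, then, this small replacement gives no clear shift in the read-out. No measurement available here accounts for the result.

As far as these compounds go, whether a methoxy group or an amine at the same position would move the number beyond the scatter remains open. Also open, from the compounds shown here alone, is whether fluoro would give a similar step with the pyrimidin-2-yl group of compound 1 in place of the 1,3-thiazol-2-yl group.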